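This account rests on a few compounds, and the source may have more. Where it says the series, first, only, none or still open, it means among the compounds named here.

Measured compounds in a functional assay on thoracic aorta for antagonist activity at Alpha-1D adrenergic receptor (Rattus norvegicus); a higher number here means a more potent compound, by a factor of ten per unit of this negative logarithm, a lower number a less potent compound:

compound 1, `COc1cccc(OC)c1OCCNCCOc1ccccc1OCc1cccc(Cl)c1`: 8.72
compound 2, `COc1cccc(OC)c1OCCNCCOc1ccccc1OCc1ccccc1C`: 8.64
compound 3, `COc1cccc(OC)c1OCCNCCOc1ccccc1OCc1ccccc1[N+](=O)[O-]`: 8.95

All three share one core and differ only in the group carried on the saturated chain carbon bound to an oxygen on the aromatic ring. Within the data shown here, compound 3 holds the highest of the three numbers, but the step of a number 0.23 log units higher from compound 1 to compound 3 (within the scatter) lies within the scatter, so compound 1 and compound 3 cannot be told apart; only the step of a number 0.31 log units higher from compound 2 to compound 3 (beyond the scatter) is beyond the scatter, and even that is modest. The step of a number 0.08 log units lower from compound 1 to compound 2 (within the scatter) is within the scatter too.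

Compound 4, `COc1ccccc1COc1ccccc1OCCNCCOc1c(OC)cccc1OC`, is the next member of this set. Its change from compound 3 is methoxy in place of nitro on an aromatic carbon. The step that bears most directly on it is the earlier exchange on the same aromatic carbon, a number 0.31 log units higher from compound 2 to compound 3 (beyond the scatter), where methyl gave way to nitro and the number rose only modestly. The whole-group exchanges, a number 0.08 log units lower from compound 1 to compound 2 (within the scatter) and a number 0.23 log units higher from compound 1 to compound 3 (within the scatter), show that swapping one substituted phenyl for another barely moves this assay. Taken together, these steps suggest that putting methoxy in place of nitro should cost little, so the expected step is a number 0.25 log units lower from compound 3 to compound 4 (within the scatter), most likely inside the scatter.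

Compound 4 is therefore estimated at 8.7, with a likely range from 8.3 to 9.1.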

Compound 4, negative logarithm of the antagonist equilibrium constant: 8.86
Compound 4: middle estimate off by 0.16 log units, on the low side; the range from low to high includes it.
By their numbers in this assay, from the lowest: compounds 2, 1, 4 and 3 (each within the scatter of the next, the first and the last beyond it).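

In this assay, methoxy on this aromatic carbon, ortho to a large group, cannot be told apart from nitro, a number 0.09 log units lower from compound 3 to compound 4 (within the scatter), or from methyl, a number 0.22 log units higher from compound 2 to compound 4 (within the scatter). The wider exchange of the whole ring substituent gives the same picture, a number 0.14 log units higher from compound 1 to compound 4 (within the scatter), so compound 4 sits within the scatter of all three other compounds, even though the step of a number 0.31 log units higher from compound 2 to compound 3 (beyond the scatter) separates two of them, if only modestly. Across these four compounds, then, methyl, nitro and methoxy on the benzyl ring all leave the number in a narrow band, and nothing available here bears on what lies behind that flatness.

From the compounds shown here alone, whether the band would hold for a group of a different kind at this carbon, such as an amine, a carboxylic acid or a longer chain in place of methoxy, stays open. Going by these compounds, with methoxy seen here only as 2-methoxyphenyl, what it would do on the other carbons of that ring stays open too.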